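The compounds below may be only part of what the source reports. "The series", "measured", "known", "first", "only" and "open" are said of these compounds alone.

For the measured compounds named here, compound 1 `CCc1ccc2oc(CSc3nnc(CNc4ccccc4)n3CC)nc2c1` is the one member of this small set with a number to its name: in an assay on isolated protein for inhibition of long-chain fatty acid transport protein 1 (Mus musculus) (a lower number here means a stronger inhibitor, a higher number a weaker inhibitor), compound 1 gives 1800 nM. Compound 2 `CCn1c(CNc2ccccc2)nnc1SCC(=O)Nc1ccc(OC)cc1`, which carries a different link from the shared core, returns only a limit of the assay, since in this assay compound 2 gives > 10000 nM. That one of the two values sits at the limit is all the evidence shown (the limit of > 10000 nM in this assay, at which 1 of the 2 values shown sits), so no measured step exists against which a change can be weighed. Compound 3 `CCn1c(CNc2ccccc2)nnc1SCc1nc2cc(OC(F)(F)F)ccc2o1` differs from compound 1 by a single change, trifluoromethoxy in place of ethyl on an aromatic carbon. With nothing beyond the scatter to point either way, the step from compound 1 to compound 3 is expected to be small a 1.1-fold higher number from compound 1 to compound 3 (0.05 log units; within the scatter), in no settled direction. Compound 3 is therefore estimated at 2000 nM in this assay, with a range from 600 nM to 7000 nM.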

Compound 3, half-maximal inhibitory concentration: 91 nM
For compound 3 the middle estimate is 22-fold (1.34 log units) above the measured one, outside the stated range (below it).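

In this assay, trifluoromethoxy in place of ethyl on this aromatic carbon gives a 20-fold lower number from compound 1 to compound 3 (1.30 log units; beyond the scatter), so the step is large and lies beyond the scatter. For the compounds shown here, this is the first measured sign that the group at this position of the six-membered aromatic ring matters, something the earlier compounds could not show without a measured step between them. The change replaces a group of carbon only with one that holds oxygen and fluorine, but no measurement shown explains why the number falls.

As far as these compounds go, it remains open whether the oxygen or the fluorine accounts for the step, a question that methoxy or trifluoromethyl on the same aromatic carbon would address. From the compounds shown here alone, it is also open whether trifluoromethoxy would have a similar effect at another carbon of that ring.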